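The compounds below may be only part of what the source reports. "The series", "measured", "known", "first", "only" and "open" are said of these compounds alone.

Compound 1 `CCC(CC)O[C@@H]1C=C(C(=O)O)C[C@H](NCc2ccc(OC(C)C)cc2)[C@H]1NC(C)=O` was examined in an ADME assay on cells (Fibroblast, Gallus gallus) for cytotoxicity, read by CCK-8 assay, with a stated time of 48 h; a higher number here means that more compound is tolerated, a lower number that less compound is tolerated. In this assay compound 1 gives > 200000 nM, which is a limit of the assay rather than a number. Compound 2 `CCC(CC)O[C@@H]1C=C(C(=O)O)C[C@H](NCc2cccc(SC(C)CC)c2)[C@H]1NC(C)=O` also reaches only a limit in this assay, giving > 200000 nM. Compound 3 `CCC(CC)O[C@@H]1C=C(C(=O)O)C[C@H](NCc2ccc(-c3ccc(SC)cc3)cc2)[C@H]1NC(C)=O` likewise gives > 200000 nM in this assay, again a limit. Compound 1 therefore stands at the limit of > 200000 nM in this assay, at which 3 of the 3 values shown sit, and no order among the three compounds can be read. Among the compounds with values here, the one measured step that touches the same position as the change now considered is a step that the two limits leave unreadable from compound 1 to compound 3, a step whose size cannot be read because both of its ends are limits. Compound 4 `CCC(CC)O[C@@H]1C=C(C(=O)O)C[C@H](NCc2ccc(-c3csc4ccccc34)cc2)[C@H]1NC(C)=O` differs from compound 1 in carrying (1-benzothiophen-3-yl in place of isopropoxy on an aromatic carbon). With three limits and no readable step, the expectation for compound 4 is simply that it sits at or beyond the limit once more, and the step expected is a step that the limit leaves unreadable from compound 1 to compound 4. Compound 4 is accordingly estimated at 300000 nM, with a range from 120000 nM to 800000 nM.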

Compound 4, half-maximal cytotoxic concentration: > 200000 nM
Compound 4: a limit, no number (the forecaster's own chance of this, stated with the estimate: 85%); the middle value is on the limit's open side.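

In this assay compound 4 gives > 200000 nM, again a limit. The steps to compound 4 from compound 1 and from compound 3 therefore cannot be read: the limit of > 200000 nM in this assay, at which 4 of the 4 values shown sit.

The compounds shown leave open whether any of these changes alters the concentration tolerated in this assay.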